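Lengthening the Unsaturated Ester Chain of Compound 2

The source may hold more compounds than are shown below. What is called first, only, known or untested is meant among the compounds shown, and "the series" means these compounds.

Compound 1, `C/C=C/C(=O)Oc1cc2c(s1)CCN([C@H](C(=O)OC)c1ccccc1Cl)C2`: 22.4%
Compound 2, `CC/C=C/C(=O)Oc1cc2c(s1)CCN([C@H](C(=O)OC)c1ccccc1Cl)C2`: 26.2%
Compound 3, `CCC/C=C/C(=O)Oc1cc2c(s1)CCN([C@H](C(=O)OC)c1ccccc1Cl)C2`: not yet measured

In a functional assay on the whole organism (Platelet) for inhibition, with Rattus norvegicus as the target, at a dose of 0.5 mg/kg (a higher number here means a stronger effect of the compound at the dose given, a lower number a weaker effect), compound 2 gives 26.2%, and compound 1 gives 22.4%; the step of a number 3.8 percentage points higher from compound 1 to compound 2 (within the scatter) leaves the two inside the scatter of each other, so neither stands apart. Within the data shown here, compound 3 differs from compound 2 in one place: methyl in place of hydrogen on a saturated chain carbon, two bonds along the chain from a double-bonded chain carbon The only measured step that bears on this change is a number 3.8 percentage points higher from compound 1 to compound 2 (within the scatter), and it stayed within the scatter, so no step beyond the scatter is expected in this assay for compound 3. Compound 3 is therefore expected to give 27%, from 15% to 40%. The step of a number 0.8 percentage points higher from compound 2 to compound 3 (within the scatter) is estimated to fall inside the scatter.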

Compound 3, a percentage reported as inhibition, in the whole organism at one dose (the size of the read-out at that dose, not a potency): 19.5%
Beside the measured number, compound 3's estimate is 7.5 percentage points above it, within the range that was stated.
By their numbers in this assay, from the lowest: compounds 3, 1 and 2 (each within the scatter of the next).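

In this assay, going from but-1-en-1-yl to pent-1-en-1-yl gives a number 6.7 percentage points lower from compound 2 to compound 3 (within the scatter), and ethyl in place of hydrogen on the saturated chain carbon bound to a double-bonded chain carbon gives a number 2.9 percentage points lower from compound 1 to compound 3 (within the scatter). Adding a methyl at this further chain carbon therefore also leaves the read-out inside the scatter, as does the larger ethyl change, so the three chains cannot be told apart here. No evidence is at hand that bears on this result. The compounds shown leave open whether a much longer chain, a phenyl ring or an amine at the end of the unsaturated ester would move the read-out beyond the scatter.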